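The compounds below may be only part of what the source reports. "The series", "measured", "known", "first", "only" and "open" are said of these compounds alone.

The compounds share one core, seen in compound 1 `CC(C)[C@H](NC(=O)COc1cccc2ccccc12)C(=O)N[C@@H](CC(=O)O)C(=O)COc1ccccc1C(F)(F)F`, and differ only in the group on an oxygen on a saturated carbon. In a functional assay on Jurkat cells (Homo sapiens) (on this read-out lower numbers stand for stronger inhibition and higher numbers for weaker inhibition), compound 1 gives > 100000 nM, which is a limit of the assay and not a number. Compound 2 `CC(C)[C@H](NC(=O)COc1cccc2ccccc12)C(=O)N[C@@H](CC(=O)O)C(=O)COc1ccc(C(N)=O)cc1` in this assay gives > 100000 nM, again a limit. Compound 3 `CC(C)[C@H](NC(=O)COc1cccc2ccccc12)C(=O)N[C@@H](CC(=O)O)C(=O)COc1ccc([N+](=O)[O-])cc1` in this assay gives > 100000 nM, also a limit. Compound 3 therefore stands exactly where the other two stand: every value in the set sits at the limit of > 100000 nM in this assay, at which 3 of the 3 values shown sit, so the steps a step that the two limits leave unreadable from compound 1 to compound 2, a step that the two limits leave unreadable from compound 1 to compound 3 and a step that the two limits leave unreadable from compound 2 to compound 3 cannot be read in size, and no order among the three compounds can be claimed. Compound 4 `CC(C)[C@H](NC(=O)COc1cccc2ccccc12)C(=O)N[C@@H](CC(=O)O)C(=O)COc1cc(F)cc(F)c1F` remains to be measured, and its difference from compound 3 is 2,3,5-trifluorophenyl in place of 4-nitrophenyl on an oxygen on a saturated carbon. Among the measured compounds shown here, no measured step bears directly on this exchange, and the three steps that exist are all unreadable, so the data give no ground for expecting a move in either direction beyond the scatter. In this assay the expected step is a number no higher from compound 3 to compound 4 (the limit leaves the size open). Compound 4 is expected to give 100000 nM, within a range from 30000 nM to 300000 nM, and most likely the assay will again report only a limit.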

Compound 4, half-maximal inhibitory concentration: 30000 nM
Compound 4: the middle estimate sits 3.3-fold (0.52 log units) above what was measured, and the stated range covers the measured number.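

In this assay, among the compounds shown here, the earlier compounds could not show whether the group on an oxygen on a saturated carbon can move the read-out at all, and their values gave no reading beyond a shared limit of the assay: the limit of > 100000 nM in this assay, at which 3 of the 4 values shown sit. Compound 4 shows that it can, and 2,3,5-trifluorophenyl in this place gives an at least 3.3-fold lower number from compound 3 to compound 4 (0.52 log units; beyond the scatter), along with an at least 3.3-fold lower number from compound 2 to compound 4 (0.52 log units; beyond the scatter) and an at least 3.3-fold lower number from compound 1 to compound 4 (0.52 log units; beyond the scatter). Each of these steps starts from a limit and so gives only a minimum size, while the steps among compound 1, compound 2 and compound 3 still cannot be read, which leaves the 2,3,5-trifluorophenyl group as the only one here tied to a measured number.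

The compounds shown leave open whether all 3 fluorine atoms are needed, since an unsubstituted phenyl or a phenyl with a single fluorine would separate the effect of the fluorine atoms from that of the ring. They also leave open whether a ring bearing an amine or a carboxylic acid, or a plain alkyl chain in place of the ring, would give a number below the limit.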